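The source may report more compounds than this note shows. Statements on the series, on what has been measured and on what is new or still open speak of the compounds shown alone.

Measured compounds:
Compound 1 `CCN(CC)CCCNC(=O)C1CN(S(=O)(=O)c2ccc(OC)c3ccccc23)c2ccccc21` — in a functional assay on CHO cells for antagonist activity at 5-hydroxytryptamine receptor 6 (Homo sapiens), read by FLIPR (a higher number here means a weaker inhibitor, a lower number a stronger inhibitor), compound 1 gives 79.4 nM.
Compound 2 `COc1ccc(S(=O)(=O)N2CC(C(=O)NCCCn3ccnc3)c3ccccc32)c2ccccc12` — in this assay compound 2 gives 79.4 nM.
Compound 3 `CN1CCC(N(C)C(=O)C2CN(S(=O)(=O)c3ccc4c(c3)OCCO4)c3ccccc32)CC1` — in this assay compound 3 gives 50.1 nM.

All three share a core carrying an aryl sulfonyl group on the ring nitrogen and an amide on the ring carbon. Compound 3 has the lowest number of the three, but its gaps to compound 1 and to compound 2 lie within the scatter, so the three compounds are not separated in this assay.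

Compound 4 `COc1cc(C)c(S(=O)(=O)N2CC(C(=O)N(C)C3CCN(C)CC3)c3ccccc32)c(C)c1C` is the next compound, and it differs from compound 3 in the aryl group on the sulfonyl sulfur: 4-methoxy-2,3,6-trimethylphenyl in place of 2,3-dihydro-1,4-benzodioxin-6-yl on a sulfonyl sulfur. Among the measured compounds shown here, the only measured step among the three, no change at the digits printed from compound 1 to compound 2 (within the scatter), concerns the chain on the amide nitrogen, not the sulfonyl aryl group, and it showed no change. For the measured compounds named here, no measured step touches the sulfonyl aryl group itself, so there is no direct guide to the direction of this change in this assay. Given that the three measured compounds all sit close together, the step of a 1.3-fold higher number from compound 3 to compound 4 (0.10 log units; within the scatter) is expected to stay near the scatter, with a wide range in either direction. Compound 4 is therefore estimated at 63 nM, between 20 nM and 200 nM.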

Compound 4, inhibition constant: 100 nM
Beside the measured number, compound 4's estimate is 1.6-fold (0.20 log units) below it; low and high end bracket the measured number.
By their numbers in this assay, from the lowest: compounds 3, 1, 2 and 4 (each within the scatter of the next).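

Among the compounds shown, this is the only step at the aryl group on a sulfonyl sulfur whose other neighbours are a sulfonamide nitrogen in a ring. In this assay, putting 4-methoxy-2,3,6-trimethylphenyl in place of 2,3-dihydro-1,4-benzodioxin-6-yl gives a 2.0-fold higher number from compound 3 to compound 4 (0.30 log units; within the scatter) and so does not separate the pair, even though the six-membered non-aromatic ring leaves and the entering group carries one hydrogen-bond acceptor against two. Nothing available explains why the two aryl groups read alike. 

As far as these compounds go, it remains open whether a plain phenyl, or a phenyl carrying a carboxylic acid or an amine, on the sulfonyl sulfur would move the number beyond the scatter in this assay or stay with these compounds. The aryl group of compound 1 stands on a different amide, so its effect at this position cannot be read alone.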